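A few compounds are considered here, and "the series" means these few. Any claim that something is new, unique, unknown or untested is made for them only; others in the source may bear on it.

Measured so far in a physicochemical assay for solubility, read by nephelometry, measured as kinetic solubility, at pH 2.0; on this read-out higher numbers stand for higher solubility and lower numbers for lower solubility:
- Compound 1 `CC(C)(C)c1cc(C(=O)Nc2cccc(CN)c2)n(Cc2ccccc2)n1`: > 100 ug/mL
- Compound 2 `CC(C)(C)c1cc(C(=O)Nc2ccncc2)n(Cc2ccccc2)n1`: > 100 ug/mL

Both entries are limits rather than numbers, and the two compounds share (the limit of > 100 ug/mL in this assay, at which 2 of the 2 values shown sit). Compound 2 therefore stands only at > 100 ug/mL, which is a limit. Compound 3 `CNCc1csc(NC(=O)c2cc(C(C)(C)C)nn2Cc2ccccc2)n1` has 4-((methylamino)methyl)-1,3-thiazol-2-yl in place of pyridin-4-yl on an amide-type nitrogen. Among the compounds with values here, the one measured step that bears on this is a step that the two limits leave unreadable from compound 1 to compound 2, so it offers no size to carry over. Within the data shown here, with only that guide, no change beyond the scatter is expected in this assay, and the estimated step is a number no higher from compound 2 to compound 3 (the limit leaves the size open). The estimate for compound 3 is 100 ug/mL, with an expected range of 60 ug/mL to 140 ug/mL.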

Compound 3, solubility: 25 ug/mL
Compound 3: middle estimate off by 4.0-fold (0.60 log units), on the high side, and the stated range ends above it.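

In this assay, within the data shown here, this is the first readable change at the group on the amide-type nitrogen: 4-((methylamino)methyl)-1,3-thiazol-2-yl in place of pyridin-4-yl gives an at least 4.0-fold lower number from compound 2 to compound 3 (0.60 log units; beyond the scatter), and in place of 3-(aminomethyl)phenyl it gives an at least 4.0-fold lower number from compound 1 to compound 3 (0.60 log units; beyond the scatter). So the read-out does respond to the group at this place. The full size of both steps stays open because compound 1 and compound 2 each stand at a limit: the limit of > 100 ug/mL in this assay, at which 2 of the 3 values shown sit.

The compounds shown leave open whether the ring or its (methylamino)methyl chain goes with the step. A plain 1,3-thiazol-2-yl group on the same nitrogen would separate the two.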